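This account rests on a few compounds, and the source may have more. Where it says the series, first, only, none or still open, it means among the compounds named here.

For the measured compounds named here, in a physicochemical assay for lipophilicity (on this read-out higher numbers stand for higher lipophilicity and lower numbers for lower lipophilicity), compound 3 (`CC(=O)OCc1ccc([N+](=O)[O-])cc1`) reads 2.02, the second highest of the three numbers measured so far. Compound 1 (`CC(=O)Oc1ccc(COC(=O)c2cnccn2)cc1`) lies lower at 0.92 and compound 2 (`CC(=O)Oc1ccc(COC(=O)c2ccccc2)cc1`) lies higher at 3.38, both gaps beyond the scatter. Compound 4 (`CC(=O)OCc1ccc(OC(C)=O)cc1`) departs from compound 3 in one place: acetoxy in place of nitro on an aromatic carbon. In short, compound 4 carries acetoxy where compound 3 carries nitro.

Going by the values given here, the only measured step is a number 2.46 log units higher from compound 1 to compound 2 (beyond the scatter). It comes with phenyl in place of pyrazin-2-yl on a carbonyl carbon, so it bears on this exchange only indirectly, as a sign of how far this assay can move with a single change. Among the compounds with values here, compound 1 and compound 2 both carry acetoxy, but no measured pair sets it against nitro, which leaves the expectation loose. The counted difference between the two groups is slight, so a modest fall is expected rather than a change of that size. The expected step is a number 0.37 log units lower from compound 3 to compound 4 (beyond the scatter). For compound 4 the estimated value is 1.65, with an expected range from 1.25 to 2.05.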

Compound 4, partition coefficient: 2.03
Compound 4: the middle estimate sits 0.38 log units below what was measured, within the range that was stated.
By their numbers in this assay, from the lowest: compound 1; then compounds 3 and 4 (each within the scatter of the next); then compound 2.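

On an aromatic carbon of the six-membered ring, para to a group of 5 heavy atoms, this assay gives a number 0.01 log units higher from compound 3 to compound 4 (within the scatter) when acetoxy stands in place of nitro, so this exchange leaves no readable change at this position. The group on the carbonyl carbon does move the number, with a number 1.35 log units lower from compound 2 to compound 4 (beyond the scatter) for methyl in place of phenyl and a number 1.11 log units higher from compound 1 to compound 4 (beyond the scatter) for methyl in place of pyrazin-2-yl, and these two large steps run in opposite directions. No supporting measurement explains either result.

Going by these compounds, it remains open whether an amine or a carboxylic acid on that aromatic carbon would also leave the number in place, or whether acetoxy and nitro are simply a matched pair. On these data alone, it is equally open where a longer chain on the carbonyl carbon would fall relative to methyl and phenyl.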